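This account rests on a few compounds, and the source may have more. Where it says the series, first, only, none or still open, it means among the compounds named here.

Measured in a functional assay on K562 cells (Homo sapiens) for antiproliferative activity, read by trypan blue exclusion, with a stated time of 48 h, tested at 10 uM; a higher number here means more inhibition of growth at the concentration tested, a lower number less inhibition of growth:
- compound 1 `NC(=O)c1cc(Br)ccc1NC(=O)/C=C/c1ccccc1Cl`: 59%
- compound 2 `NC(=O)c1cc(Br)ccc1NC(=O)/C=C/c1ccc(Cl)cc1`: 22%

Compound 2, at 22%, holds the lower of the two numbers. Among the measured compounds shown here, the only measured step is a number 37 percentage points lower from compound 1 to compound 2 (beyond the scatter), a large one in which 4-chlorophenyl replaces 2-chlorophenyl at the same place on the chain.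

Next is compound 3 `Cc1cccc(/C=C/C(=O)Nc2ccc(Br)cc2C(N)=O)c1`, which differs from compound 2 as follows: 3-methylphenyl in place of 4-chlorophenyl on a double-bonded chain carbon bound to a double-bonded chain carbon. For the measured compounds named here, the 3-methylphenyl group has no measured counterpart. Going by the values given here, the one step, a number 37 percentage points lower from compound 1 to compound 2 (beyond the scatter), therefore shows only that changing this aryl group can move the number a long way. Since compound 2 sits at the low end, a moderate rise in this assay is expected, though with low confidence. The expected change is a number 13 percentage points higher from compound 2 to compound 3 (beyond the scatter). For compound 3 the estimated value is 35%, with an expected range of 15% to 58%.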

Compound 3, percent growth inhibition at one concentration: 43.8%
Compound 3: middle estimate off by 8.8 percentage points, on the low side; measured number inside the range.
By their numbers in this assay, from the lowest: compound 2; then compound 3; then compound 1.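

The step to 3-methylphenyl gives a number 21.8 percentage points higher from compound 2 to compound 3 (beyond the scatter) in this assay, and the same group gives a number 15.2 percentage points lower from compound 1 to compound 3 (beyond the scatter). The three aryl groups at this chain carbon therefore give three separate levels, and a group with no chlorine, the 3-methylphenyl of compound 3, stands above the 4-chlorophenyl of compound 2 but short of the 2-chlorophenyl of compound 1. Nothing available on these compounds accounts for this order.

Open, going by these compounds, is whether the order follows the kind of substituent or its place on the phenyl ring, as methyl and chlorine never share a ring place in these three compounds. Also open, on these data alone, is how an amine or a carboxylic acid on that phenyl ring would rank against these three.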